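A few compounds are considered here, and "the series" means these few. Any claim that something is new, unique, unknown or untested is made for them only; others in the source may bear on it.

Measured so far:
- Compound 1, `O=[N+]([O-])c1ccc(-n2cc(-c3ccc(C(F)(F)F)cc3)cn2)cc1`: in a functional assay on BGC-823 cells (Homo sapiens) for cytotoxicity, read by MTT assay, with a stated time of 48 h (a lower number here means a stronger inhibitor, a higher number a weaker inhibitor), compound 1 gives 13800 nM.
- Compound 2, `O=[N+]([O-])c1ccc(-c2cnn(-c3ccc([N+](=O)[O-])cc3)c2)cc1`: in this assay compound 2 gives 11900 nM.
- Compound 3, `Cc1nn(-c2ccc([N+](=O)[O-])cc2)c(C)c1-c1cccc(-c2c(C)nn(-c3ccc([N+](=O)[O-])cc3)c2C)c1`: in this assay compound 3 gives 11900 nM.

All three numbers sit close together. For the measured compounds named here, the only step between compounds that differ in one place is a 1.2-fold lower number from compound 1 to compound 2 (0.06 log units; within the scatter), which is within the scatter. Compound 3 stands level with compound 2 at the digits printed, and the two share the lowest number of the three; compound 1 lies a little higher, but that gap is also within the scatter, so no ordering among them can be claimed.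

Compound 4, `CCCCCCCCOc1cc(-c2c(C)nn(-c3ccc([N+](=O)[O-])cc3)c2C)cc(-c2c(C)nn(-c3ccc([N+](=O)[O-])cc3)c2C)c1`, differs from compound 3 by octyloxy in place of hydrogen on an aromatic carbon. Going by the values given here, no measured step touches a change of this kind: the one step on hand swaps a group on a ring far from this position, and it made no difference beyond the scatter. The data therefore give no ground to expect the octyloxy group to move the number in either direction, and the expectation is a step of no more than the scatter, so compound 4 is expected to stay near compound 3, with a 1.0-fold higher number from compound 3 to compound 4 (0.00 log units; within the scatter). The estimate for compound 4 in this assay is 12000 nM, between 4000 nM and 36000 nM.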

Compound 4, half-maximal inhibitory concentration: 8400 nM
Compound 4: the middle estimate sits 1.4-fold (0.15 log units) above what was measured; low and high end bracket the measured number.
By their numbers in this assay, from the lowest: compounds 4, 2, 3 and 1 (each within the scatter of the next).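

In this assay, for the compounds shown here, the first change at this position, octyloxy in place of hydrogen on an aromatic carbon meta to two large groups, gives a 1.4-fold lower number from compound 3 to compound 4 (0.15 log units; within the scatter). Going by these compounds alone, this is a sizeable addition of 9 heavy atoms with no ring, yet the step stays within the usual scatter of repeated measurements, so this place on the ring can carry a long chain without a clear change in the number, something the earlier compounds, which hold only hydrogen here, could not show. No measurement is available that would tell what the chain does in these cells, so the small step carries no explanation.

The compounds shown leave open whether any group at this position can move the number beyond the scatter, since a single chain says little about how a short methoxy group, a longer dodecyloxy chain, an amine or a carboxylic acid would behave there. They also leave open whether octyloxy would give the same small step on another core, since it appears here on only one.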